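The compounds below may be only part of what the source reports. "The series", "measured", "known", "first", "only" and "open" are said of these compounds alone.

Measured so far:
compound 1 `COc1ccc(/C=N/NC(=O)Nc2ccc(Oc3ccnc(-c4nncn4CCN(C)C)c3)c(F)c2)c(OC)c1OC` — 2020 nM in a functional assay on MKN-45 cells (Homo sapiens) for cytotoxicity, read by MTT assay, with a stated time of 72 h; on this read-out higher numbers stand for weaker inhibition and lower numbers for stronger inhibition
compound 2 `CN(C)CCn1cnnc1-c1cc(Oc2ccc(NC(=O)N/N=C/c3cc(Br)c(O)c(Br)c3)cc2F)ccn1` — 4320 nM in this assay

Among these two numbers compound 2 stands highest in this assay; its nearest neighbour is compound 1, separated by the one measured step, a 2.1-fold higher number from compound 1 to compound 2 (0.33 log units; beyond the scatter). That step bears on the present question only loosely: it swaps one aryl group for another on the same carbon with a double bond to nitrogen, and it was modest.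

Compound 3 `CN(C)CCn1cnnc1-c1cc(Oc2ccc(NC(=O)N/N=C/c3ccc(O)c(F)c3)cc2F)ccn1` is not yet measured. It differs from compound 2 in one place: 3-fluoro-4-hydroxyphenyl in place of 3,5-dibromo-4-hydroxyphenyl on a carbon with a double bond to nitrogen. Among the measured compounds shown here, no measured pair tests this particular exchange, and the one step available at the same position was modest, so for this assay no step beyond the scatter is expected, perhaps a slight movement back toward the number of compound 1. Compound 3 is therefore estimated at 3500 nM, within 1500 nM to 8000 nM, which as a step means an expected 1.2-fold lower number from compound 2 to compound 3 (0.09 log units; within the scatter).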

Compound 3, half-maximal inhibitory concentration: 1970 nM
Estimate against measurement, compound 3: 1.8-fold (0.25 log units) above; the range from low to high includes it.
By their numbers in this assay, from the lowest: compounds 3 and 1 (each within the scatter of the next); then compound 2.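

In this assay, 3-fluoro-4-hydroxyphenyl in place of 3,5-dibromo-4-hydroxyphenyl on the carbon with a double bond to nitrogen gives a 2.2-fold lower number from compound 2 to compound 3 (0.34 log units; beyond the scatter) and shows that the number at this position moves with the substituents on a hydroxyphenyl group, not only with a change from methoxy groups to a hydroxyl. The same group in place of 2,3,4-trimethoxyphenyl gives a 1.0-fold lower number from compound 1 to compound 3 (0.01 log units; within the scatter) and so does not separate these two differently substituted rings. Of the three, compound 2 alone stands apart, with the highest number.

Open, as far as these compounds go, is whether a single bromine on the hydroxyphenyl group, or an amine or a carboxylic acid there, would move the number outside the span of these three compounds. Nothing available explains the differences seen at this position.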